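A few compounds are considered here, and "the series" means these few. Any claim that something is new, unique, unknown or untested is made for them only; others in the source may bear on it.

Measured so far in an assay on isolated protein for inhibition of DNA topoisomerase 1 (Homo sapiens), with a stated time of 30 min, tested at 100 uM; a lower number here means a weaker effect, a higher number a stronger effect of the compound at the concentration tested:

compound 1 `Oc1ccccc1-c1cc(-c2ccccc2)cc(-c2ccccc2O)n1`: 0%
compound 2 `Oc1cccc(-c2cc(-c3ccccc3)cc(-c3ccccc3)n2)c1`: 12.9%
compound 3 `Oc1cccc(-c2cc(-c3ccccc3)cc(-c3ccco3)n2)c1`: 10.2%

Among these three numbers compound 3 stands second highest. Its nearest neighbour is compound 2, whose number lies within the scatter of that of compound 3, so no order between the two can be claimed. Its furthest neighbour is compound 1, whose number lies beyond the scatter below that of compound 3.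

Compound 4 `Oc1cccc(-c2cc(-c3ccccc3)cc(-c3cccc(O)c3)n2)c1` has not yet been measured in this assay. It differs from compound 3 in one place: 3-hydroxyphenyl in place of furan-2-yl on an aromatic carbon. Going by the values given here, the only measured step that touches this place is the one from compound 2 to compound 3, where a number 2.7 percentage points lower from compound 2 to compound 3 (within the scatter). That step exchanged phenyl for furan-2-yl at the same carbon and left the number essentially where it was. Among the compounds with values here, no measured step puts a 3-hydroxyphenyl at this carbon, so the size of such a change is unknown; compound 1, which carries two hydroxyphenyl groups of a different kind, gives a number not far from the others.

Compound 4 is therefore expected to give a number close to that of compound 3, with a step of a number 1.8 percentage points higher from compound 3 to compound 4 (within the scatter). The estimate for compound 4 is 12%, between 0% and 25%.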

Compound 4, a percentage reported as inhibition, at one concentration (the size of the read-out at that concentration, not a potency): 67.2%
Beside the measured number, compound 4's estimate is 55.2 percentage points below it; measured number outside the range, above it.
By their numbers in this assay, from the lowest: compound 1; then compounds 3 and 2 (each within the scatter of the next); then compound 4.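

In this assay the carbon next to the ring nitrogen had looked indifferent, with a number 2.7 percentage points lower from compound 2 to compound 3 (within the scatter) for furan-2-yl in place of phenyl, but the new result shows that what sits here can matter a great deal: a number 57 percentage points higher from compound 3 to compound 4 (beyond the scatter) when 3-hydroxyphenyl replaces furan-2-yl. The clearest comparison is a number 54.3 percentage points higher from compound 2 to compound 4 (beyond the scatter). Hydroxy in place of hydrogen on an aromatic carbon is the only change in that step, and the large rise goes with this one hydroxy group on a phenyl ring, in a molecule that already carries a 3-hydroxyphenyl group. Nothing available explains why adding this group has such a large effect.

As far as these compounds go, whether a methoxy or an amine at the same spot on that phenyl ring would give a similar number remains open, as does whether a hydroxy group elsewhere on the ring would do the same. Compound 1 carries hydroxyphenyl groups of a different kind but differs from compound 4 in more than one place, so it cannot settle the second question.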